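The source may hold more compounds than are shown below. What is called first, only, known or untested is meant among the compounds shown, and "the series" means these compounds.

Compound 1 (`CC(=O)SCCC(CCCCC(=O)O)SC(C)=O`): 1.61%
Compound 2 (`O=C(O)CCCCC(CCSC(=O)c1ccccc1)SC(=O)c1ccccc1`): "not active" (no number reported)
Compound 3 (`O=C(CCCCC(S)CCS)Nc1cccc2ccccc12`): "not active" (no number reported)

Within the data shown here, in a functional assay on HO8910 cells (Homo sapiens) for inhibition, read by MTT assay, with a stated time of 24 h, tested at 10 ug/mL (a lower number here means less inhibition of growth, a higher number more inhibition of growth at the concentration tested), compound 1 gives 1.61%, a small value and the only number available. Compound 2 gives "not active" (no number reported) and compound 3 gives "not active" (no number reported), so neither offers a number for comparison.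

Compound 4 (`CC(=O)SCCC(CCCCC(=O)Nc1ccccc1Cl)SC(C)=O`) keeps the core of compound 1 and changes one group: (2-chlorophenyl)amino in place of hydroxy on a carbonyl carbon. Among the measured compounds shown here, no measured pair shows this change alone. Compound 3 is also an amide with aromatic rings, yet gives "not active" (no number reported), which argues for caution. A modest rise in this assay is expected, close to the usual scatter: a number 10.4 percentage points higher from compound 1 to compound 4 (beyond the scatter). Compound 4 is estimated at 12%, with an expected range of 1% to 35%.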

Compound 4, percent growth inhibition at one concentration: "not active" (no number reported)
For compound 4 the study gives words and no number; the estimate stays without a comparison.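

Among these compounds, compound 4 is reported in words without a number, and no step from compound 1 to compound 4 can be read. The compounds shown leave open whether, in this assay, (2-chlorophenyl)amino in place of hydroxy changes growth inhibition. No measurement shown here offers an explanation.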